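A few compounds are considered here, and "the series" means these few. Any claim that something is new, unique, unknown or untested is made for them only; others in the source may bear on it.

Compound 1 `Clc1cccc(Cc2nnc(Cn3nnc4ccccc43)o2)c1` and compound 2 `Fc1cccc(Cc2nnc(Cn3nnc4ccccc43)o2)c1` share one core, while compound 3 `Clc1cccc(-c2nnc(Cn3nnc4ccccc43)o2)c1` and compound 4 `Fc1cccc(-c2nnc(Cn3nnc4ccccc43)o2)c1` share another; the difference between the two cores is not broken down here. In a functional assay on HeLa cells (Homo sapiens) for antiproliferative activity, read by MTT assay, with a stated time of 24 h (on this read-out lower numbers stand for stronger inhibition and higher numbers for weaker inhibition), compound 1 gives 230000 nM, and compound 2 gives 237000 nM in this assay. The change between them, (fluoro in place of chloro on an aromatic carbon), produced a 1.0-fold higher number from compound 1 to compound 2 (0.01 log units; within the scatter). Compound 3 gives 327000 nM in this assay, and all three measured values lie within the scatter of one another. Compound 4 carries the same change, (fluoro in place of chloro on an aromatic carbon), on the other core. Because the earlier step of a 1.0-fold higher number from compound 1 to compound 2 (0.01 log units; within the scatter) was within the scatter, the step to compound 4 is expected to be a 1.0-fold higher number from compound 3 to compound 4 (0.00 log units; within the scatter). Compound 4 is therefore estimated at 330000 nM in this assay, expected between 180000 nM and 600000 nM.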

Compound 4, half-maximal inhibitory concentration: 332000 nM
Compound 4: the middle estimate sits 1.0-fold (0.00 log units) below what was measured, within the range that was stated.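

In this assay, fluoro in place of chloro on the core of compound 3 gave a 1.0-fold higher number from compound 3 to compound 4 (0.01 log units; within the scatter) on this core. Set beside the earlier step, the change carries across the two cores with no difference that can be read: the same change on two cores in this assay, a 1.0-fold higher number (0.01 log units; within the scatter) from compound 1 to compound 2 and a 1.0-fold higher number (0.01 log units; within the scatter) from compound 3 to compound 4, 1.0-fold (0.01 log units) apart, within the scatter of two such steps. For the compounds shown here, this shows only that the swap left the number unmoved on both cores; with just two pairs and one place on the ring, it does not show that a step large enough to read would carry over in the same way.

The compounds shown leave open how an amine or a carboxylic acid in place of the halogen would read in this assay. They also leave open how the same ring with no halogen at all would read on either core.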